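The compounds below may be only part of what the source reports. "The series", "measured", "known", "first", "only" and "open" are said of these compounds alone.

Compound 1 `Cc1cn([C@@H]2O[C@H](CO)[C@@H](CO)[C@H]2O)c(=O)[nH]c1=O` gives > 100 uM in a functional assay on L1210 cells (Mus musculus) for antiproliferative activity, with a stated time of 72 h; on this read-out lower numbers stand for an effect already at smaller amounts and higher numbers for an effect only at larger amounts of compound; this value is a limit of the assay.
Compound 2 `Cc1cn([C@@H]2O[C@H](CO)[C@@H](CF)[C@H]2O)c(=O)[nH]c1=O` gives > 100 uM in this assay, again a limit.
Compound 3 `Cc1cn([C@H]2C[C@H](CF)[C@@H](CO)O2)c(=O)[nH]c1=O` gives > 100 uM in this assay, also a limit.

Compound 2 therefore stands only at the limit, as do both neighbours (the limit of > 100 uM in this assay, at which 3 of the 3 values shown sit). Compound 4 `Cc1cn([C@@H]2O[C@H](CO)[C@@H](CF)[C@@H]2O)c(=O)[nH]c1=O` differs from compound 2 as follows: the two compounds have the same atoms and bonds and differ only in configuration as drawn: 1 of 4 stereo elements differ; a stereocentre at a saturated ring carbon is drawn R in compound 2 and S in compound 4. The measured steps that touch compound 2 are a step that the two limits leave unreadable from compound 1 to compound 2 and a step that the two limits leave unreadable from compound 2 to compound 3, and both run from one limit to another, so their size cannot be read. Going by the values given here, no measured step changes a stereocentre alone. Since every value shown sits at the limit (the limit of > 100 uM in this assay, at which 3 of the 3 values shown sit), no step beyond the scatter can be foreseen here. Compound 4 is expected to remain at a limit, the estimated step being a step that the limit leaves unreadable from compound 2 to compound 4. The estimate for compound 4 is 150 uM, ranging from 50 uM to 500 uM.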

Compound 4, concentration for half-maximal effect: > 100 uM
Compound 4: no number, only a limit; the forecaster's own chance of this, stated with the estimate: 85%; the middle value is on the limit's open side.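

The steps from compound 2 to compound 4 and from compound 3 to compound 4 cannot be read, since each runs between two limits: the limit of > 100 uM in this assay, at which 4 of the 4 values shown sit.

The compounds shown leave open whether the configuration at that ring carbon matters in this assay, and at what concentration any of them would act.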